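The source may report more compounds than this note shows. Statements on the series, on what has been measured and on what is new or still open speak of the compounds shown alone.

Measured compounds:
- Compound 1, `Cc1coc(C(=O)CCCCCCc2ccccc2)n1`: 520 nM
- Compound 2, `CSc1coc(C(=O)CCCCCCc2ccccc2)n1`: 29 nM
- Compound 3, `O=C(CCCCCCc1ccccc1)c1nc(C(=O)C(F)(F)F)co1`: 470 nM

All three were tested in an assay on isolated protein for inhibition of Fatty-acid amide hydrolase 1 (Rattus norvegicus); on this read-out higher numbers stand for weaker inhibition and lower numbers for stronger inhibition. Compound 1 gives the highest number of the three: compound 3 sits nearest, a 1.1-fold lower number from compound 1 to compound 3 (0.04 log units; within the scatter), while compound 2 sits furthest, an 18-fold lower number from compound 1 to compound 2 (1.25 log units; beyond the scatter). The gap between compound 2 and compound 3 is likewise large, a 16-fold higher number from compound 2 to compound 3 (1.21 log units; beyond the scatter).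

Compound 4, `O=C(CCCCCCc1ccccc1)c1nc(-c2cccnc2)co1`, has not been measured. It differs from compound 1 in one place: pyridin-3-yl in place of methyl on an aromatic carbon.

Two measured steps start from the same carbon of compound 1 and swap out the same methyl. One of them, an 18-fold lower number from compound 1 to compound 2 (1.25 log units; beyond the scatter), is large and lowers the number; the other, a 1.1-fold lower number from compound 1 to compound 3 (0.04 log units; within the scatter), stays within the scatter. For the measured compounds named here, neither replacement is a six-membered aromatic ring, so no measured step matches the change to compound 4 directly. What the two steps do show is that exchanging the methyl at this carbon has either left the number where it was or lowered it, and has not raised it. On that basis compound 4 is expected to give a number at or below that of compound 1, with an 8.7-fold lower number from compound 1 to compound 4 (0.94 log units; beyond the scatter) as the estimated step, though the size is uncertain. The estimate for compound 4 is 60 nM, within a range from 10 nM to 400 nM.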

Compound 4, inhibition constant: 18 nM
Estimate against measurement, compound 4: 3.3-fold (0.52 log units) above; measured number inside the range.
By their numbers in this assay, from the lowest: compounds 4 and 2 (each within the scatter of the next); then compounds 3 and 1 (each within the scatter of the next).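

In this assay, pyridin-3-yl on this aromatic carbon brings a large change, a 29-fold lower number from compound 1 to compound 4 (1.46 log units; beyond the scatter), showing that a six-membered aromatic ring can take the place of methyl here and still give a low number. This ring lands level with the small sulfur-linked group, as a 1.6-fold lower number from compound 2 to compound 4 (0.21 log units; within the scatter) shows, so two very different replacements end up within the scatter of each other. The remaining step, a 26-fold lower number from compound 3 to compound 4 (1.42 log units; beyond the scatter), shows that the identity of the entering group matters, since the (trifluoromethyl)carbonyl group of compound 3 does not reach this level even though it also replaces the methyl at the same carbon.

Nothing among the data given explains why these groups differ in this way. Going by these compounds, it remains open whether the ring nitrogen of pyridin-3-yl contributes to the result at all, a question that a plain phenyl ring would address, and whether moving that nitrogen, as in pyridin-2-yl or pyridin-4-yl, would change the number.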